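Adding a 4-Methoxyphenyl Group to an Aminothiophene Ester

The compounds below may be only part of what the source reports. "The series", "measured", "known", "first", "only" and "open" are said of these compounds alone.

Compound 1 `CCOC(=O)c1c(-c2cccc(C(F)(F)F)c2)csc1N`: 9.4 uM
Compound 2 `Nc1sc(-c2ccc(Cl)cc2)c(-c2cccc(C(F)(F)F)c2)c1C(=O)c1ccccc1`: > 10 uM

Of the compounds shown here, two sharing an aminothiophene core have been tested in a functional assay on CHO-K1 cells for agonist activity at adenosine receptor A1 (Homo sapiens), read by GTPgammaS binding; a lower number here means that less compound is needed, a higher number that more compound is needed for the effect. Compound 1 `CCOC(=O)c1c(-c2cccc(C(F)(F)F)c2)csc1N` gives 9.4 uM in this assay. Compound 2 `Nc1sc(-c2ccc(Cl)cc2)c(-c2cccc(C(F)(F)F)c2)c1C(=O)c1ccccc1` reaches only the limit of the assay in this assay, > 10 uM, so no number is available for it. Among the compounds with values here, compound 1 therefore stands as the only compound with a measured value; the other result is a limit, as the limit of > 10 uM in this assay, at which 1 of the 2 values shown sits, records.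

Compound 3 `CCOC(=O)c1c(N)sc(-c2ccc(OC)cc2)c1-c1cccc(C(F)(F)F)c1` has not yet been measured. Its structure differs from compound 1 by 4-methoxyphenyl in place of hydrogen on an aromatic carbon. Within the data shown here, no measured pair differing only in this place is available, and compound 2 carries two changes at once, so its limit shows only that such a compound can fall outside the range of this assay.

The step from compound 1 to compound 3 is expected to be modest, a 1.6-fold lower number from compound 1 to compound 3 (0.19 log units; within the scatter), toward somewhat less compound being needed. Compound 3 is thus estimated at 6 uM, within a range from 1.5 uM to 25 uM.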

Compound 3, concentration for half-maximal effect: > 10 uM
Compound 3: a limit, no number; the forecaster's own chance of this, stated with the estimate: 40%; middle value at least 1.6-fold (0.22 log units) from the limit.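

Within the data shown here, compound 3 gives the first reading of a single change at this place, the aromatic carbon next to the ring sulfur, with everything else in the core of compound 1 held fixed. In this assay the result for compound 3 is a limit and not a number, so the step is only a floor: an at least 1.0-fold higher number from compound 1 to compound 3 (0.02 log units; that floor lies within the scatter). The change therefore gives no sign of reducing the amount of compound needed, although the floor itself does not separate a result within the scatter from a larger rise, and with this one change the series moves further toward the limit: the limit of > 10 uM in this assay, at which 2 of the 3 values shown sit.

From the compounds shown here alone, what stays open is how far compound 3 lies beyond that limit, and so how large the effect of adding 4-methoxyphenyl really is. The compounds shown also leave open whether a smaller group at this place, such as a methyl group or a chlorine atom, or a phenyl ring without the methoxy group, would give a number that can be read in this assay.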